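Nitro substitution on the dihydropyridine aryl group: expected inhibition

This account rests on a few compounds, and the source may have more. Where it says the series, first, only, none or still open, it means among the compounds named here.

Measured so far:
compound 1 `CCOC(=O)C1=C(C)N(c2ccccc2)C=CC1c1ccccc1` — -37.1%
compound 2 `CCOC(=O)C1=C(C)N(c2ccc(Br)cc2)C=CC1c1ccccc1` — -32.1%

In a functional assay for inhibition, using microsomes, tested at 200 ug/mL (on this read-out lower numbers stand for a stronger effect and higher numbers for a weaker effect at the one concentration tested), compound 1 gives the lowest of the two numbers, with compound 2 its nearest neighbour; the step of a number 5 percentage points higher from compound 1 to compound 2 (within the scatter) lies within the scatter, so the two cannot be ordered.

Compound 3 `CCOC(=O)C1=C(C)N(c2ccccc2)C=CC1c1ccccc1[N+](=O)[O-]` is not yet measured. It differs from compound 1 by nitro in place of hydrogen on an aromatic carbon, placed on an aromatic carbon of a six-membered aromatic ring of carbon only, ortho to a large group.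

For the measured compounds named here, the only measured step, a number 5 percentage points higher from compound 1 to compound 2 (within the scatter), concerns a different ring and a different group; it offers no direct precedent. With just one aromatic substitution on record, and that one within the scatter, no movement beyond the scatter is expected in this assay for compound 3, in either direction.

For compound 3 the expected step is a number 4.1 percentage points higher from compound 1 to compound 3 (within the scatter). Compound 3 is therefore estimated at -33%, in the range -50% to -15%.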

Compound 3, a percentage reported as activity, at one concentration (the size of the read-out at that concentration, not a potency): -25.1%
Estimate against measurement, compound 3: 7.9 percentage points below, and the stated range covers the measured number.
By their numbers in this assay, from the lowest: compounds 1, 2 and 3 (each within the scatter of the next, the first and the last beyond it).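

In this assay, for the compounds shown here, the change from phenyl to 2-nitrophenyl gives a number 12 percentage points higher from compound 1 to compound 3 (beyond the scatter), the first step that clears the usual scatter, so this aromatic carbon, ortho to a large group, is not indifferent to substitution. The direction is toward a weaker effect at the one concentration tested, and the size is modest; the earlier step, a number 5 percentage points higher from compound 1 to compound 2 (within the scatter), involved bromo on a different ring and could not be ordered. Nothing available explains the shift at this position.

On these data alone, whether the shift belongs to nitro itself or to any group at this place remains open, as an amine, a methoxy group or a carboxylic acid on the same aromatic carbon would test. Also open, as far as these compounds go, is how nitro would read on other carbons of this ring.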